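The source may report more compounds than this note shows. Statements on the series, on what has been measured and on what is new or still open speak of the compounds shown alone.

Working notes on the series.

Compound 1 `CC(=O)N1CCN(c2nnc3nncn3n2)CC1` and compound 2 `CCC(=O)N1CCN(c2nnc3nncn3n2)CC1` share one core and differ in a single place. In a functional assay on HL-60 cells (Homo sapiens) for inhibition, read by MTT assay, with a stated time of 72 h (on this read-out higher numbers stand for weaker inhibition and lower numbers for stronger inhibition), compound 1 gives 14700 nM and compound 2 gives 10100 nM. The difference between them is methyl in place of hydrogen on a saturated chain carbon bound to a carbonyl carbon, and the step it made is a 1.5-fold lower number from compound 1 to compound 2 (0.16 log units; within the scatter). Compound 3 `CCCNc1nnc2nncn2n1` is built on a different core; the difference between the two cores is not broken down here. In this assay compound 3 gives 15100 nM, a number that lies within the scatter of the numbers for compound 1 and compound 2, so nothing can be said of order among the three.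

Compound 4 `CCCCNc1nnc2nncn2n1` is not yet measured. It differs from compound 3 by methyl in place of hydrogen on a saturated chain carbon, three bonds along the chain from a nitrogen on an aromatic ring. This is the same kind of change as that from compound 1 to compound 2, though not the same: in one case the place is a saturated chain carbon bound to a carbonyl carbon, in the other a saturated chain carbon, three bonds along the chain from a nitrogen on an aromatic ring.

Among the measured compounds shown here, the only precedent rests on one pair, and the step it made stayed within the scatter. The step from compound 3 to compound 4 is therefore expected to be about a 1.4-fold lower number from compound 3 to compound 4 (0.14 log units; within the scatter) in this assay, because the earlier step was a 1.5-fold lower number from compound 1 to compound 2 (0.16 log units; within the scatter). Compound 4 is estimated at 11000 nM in this assay, with a range expected from 5000 nM to 26000 nM, the wide range reflecting that the two places are not alike and that the cores differ.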

Compound 4, half-maximal inhibitory concentration: 36200 nM
Compound 4: the middle estimate sits 3.3-fold (0.52 log units) below what was measured; the whole stated range lies below it.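

In this assay going from propyl to butyl gave a 2.4-fold higher number from compound 3 to compound 4 (0.38 log units; beyond the scatter) and this step, though modest, lies beyond the scatter. Set beside the earlier pair, the same change did not carry over from one core to the other in this assay: the same change on two cores in this assay, a 1.5-fold lower number (0.16 log units; within the scatter) from compound 1 to compound 2 and a 2.4-fold higher number (0.38 log units; beyond the scatter) from compound 3 to compound 4, 3.5-fold (0.54 log units) apart, beyond the scatter of two such steps
What this does not show is the reason for the gap, since the places differ along with the cores: one is a saturated chain carbon bound to a carbonyl carbon, the other a saturated chain carbon, three bonds along the chain from a nitrogen on an aromatic ring, and with a single pair on each side neither difference can be separated from the other, nor can a rule for the series be drawn.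

The compounds shown leave open whether a longer chain such as pentyl would extend the step seen from propyl to butyl, and whether a butanoyl group on the core of compound 1 would stay as close to its neighbours as the acetyl and propanoyl groups do. They also leave open what an amine or a carboxylic acid in place of these chains would give on either core.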